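Methyl on the aryl sulfone: a tolerance check

The source may report more compounds than this note shows. Statements on the series, on what has been measured and on what is new or still open speak of the compounds shown alone.

Measured compounds in an ADME assay on THP-1 cells (Homo sapiens) for cytotoxicity, read by flow cytometry and propidium iodide staining, with a stated time of 72 h; on this read-out higher numbers stand for weaker inhibition and lower numbers for stronger inhibition:
- compound 1 `Cn1cnc(CS(=O)(=O)c2ccccc2)c1[N+](=O)[O-]` gives > 888000 nM, a limit of the assay.
- compound 2 `Cc1ccc(S(=O)(=O)Cc2ncn(C)c2[N+](=O)[O-])cc1` gives > 846000 nM, a limit of the assay.
- compound 3 `Cc1nc(CS(=O)(=O)c2ccccc2)c([N+](=O)[O-])n1CCO` gives > 768000 nM, a limit of the assay.

All three values are limits, so none of them is a number. The change from compound 1 to compound 2 is methyl in place of hydrogen on an aromatic carbon, and the step that the two limits leave unreadable from compound 1 to compound 2 cannot be read because both values are limits. The core of compound 3 differs from that of compound 1, but that difference is not broken down here.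

Compound 4 `Cc1ccc(S(=O)(=O)Cc2nc(C)n(CCO)c2[N+](=O)[O-])cc1` is not yet measured. It carries the same kind of change as compound 2 does: methyl in place of hydrogen on an aromatic carbon. Since compound 3 sits at a limit with > 768000 nM, and the matching change left compound 2 at a limit too, compound 4 is expected to stay at a limit, with an expected step that the limit leaves unreadable from compound 3 to compound 4 that is essentially flat. The estimate for compound 4 is 850000 nM, spanning 300000 nM to 2500000 nM.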

Compound 4, half-maximal inhibitory concentration: 59000 nM
Compound 4: middle estimate off by 14-fold (1.16 log units), on the high side; measured number outside the range, below it.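

In this assay, the phenyl to 4-methylphenyl change gives an at least 13-fold lower number from compound 3 to compound 4 (1.11 log units; beyond the scatter), a step beyond the usual scatter. That size is only a minimum, since the starting point is a limit of the assay and not a number: the limit of > 768000 nM in this assay, at which 1 of the 4 values shown sits. On the core of compound 1 the same change gives a step that cannot be read, and compound 2 gives > 846000 nM, which is also a limit, so a clear drop is seen on one core only and these compounds cannot say why the two cores part ways.

As far as these compounds go, two pairs are a thin base for any rule, so it remains open whether the large step belongs to the methyl itself or would also appear with another group in the same place, such as chlorine, methoxy or a longer chain like ethyl. From the compounds shown here alone, it also remains open whether a third core would follow compound 3 and compound 4, or compound 1 and compound 2.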